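Same Atoms, Different Places: From Compound 2 to Compound 3

A few compounds are considered here, and "the series" means these few. Any claim that something is new, unique, unknown or untested is made for them only; others in the source may bear on it.

Compound 1 `N#Cc1cccc(OC(=O)N2CCC(OC(c3ccccc3)c3ccccc3)CC2)c1` and compound 2 `N#Cc1ccc(F)c(OC(=O)N2CCC(C(c3ccccc3)c3ccccc3)CC2)c1` share a core that carries a substituted phenyl group on an oxygen next to a carbonyl group. In an assay on isolated protein for inhibition of Fatty-acid amide hydrolase 1 (Rattus norvegicus), read by fluorescence (a higher number here means a weaker inhibitor, a lower number a stronger inhibitor), compound 1 gives > 1000 nM, which is a limit of the assay rather than a measured number. In this assay compound 2 likewise gives only a limit, > 1000 nM. Compound 2 therefore stands where every value shown so far sits, at the ceiling described by the limit of > 1000 nM in this assay, at which 2 of the 2 values shown sit, with no number to place it any more precisely than that.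

Compound 3 `N#Cc1cc(F)cc(OC(=O)N2CCC(C(c3ccccc3)c3ccccc3)CC2)c1` is built from the same atoms as compound 2, joined differently: 3-cyano-5-fluorophenyl in place of 5-cyano-2-fluorophenyl on an oxygen next to a carbonyl group. Among the compounds with values here, no step between two measured compounds shows what such a rearrangement of the ring substituents does in this assay, so the expectation rests only on where compound 2 stands. The expected step that the limit leaves unreadable from compound 2 to compound 3 is none beyond the scatter. Compound 3 is thus estimated at 3000 nM, with a range from 1000 nM to 15000 nM, and most likely again reported only as a limit.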

Compound 3, half-maximal inhibitory concentration: > 1000 nM
Compound 3: a limit, no number; the forecaster's own chance of this, stated with the estimate: 75%; the middle value does not contradict the limit.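

In this assay compound 3 gives > 1000 nM as a limit of the assay, not a number. Compound 2 also has only a limit, so no step can be read between compound 2 and compound 3, and all the compounds shown sit at one ceiling: the limit of > 1000 nM in this assay, at which 3 of the 3 values shown sit. On these data alone, what stays open is how strongly compound 1, compound 2 and compound 3 each inhibit the enzyme, and whether the 3-cyano-5-fluorophenyl and 5-cyano-2-fluorophenyl groups differ at all.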